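Swapping 4-methylphenyl for phenyl on the ring nitrogen

The source may report more compounds than this note shows. Statements on the series, on what has been measured and on what is new or still open speak of the compounds shown alone.

Compound 1 `COc1cccc(N2C(=O)COc3ccc(-c4cnc(Cl)c(NS(=O)(=O)c5ccc(F)cc5)c4)cc32)c1`: > 40000 nM
Compound 2 `O=C1COc2ccc(-c3cnc(Cl)c(NS(=O)(=O)c4ccc(F)cc4)c3)cc2N1`: 15600 nM
Compound 3 `Cc1ccc(N2C(=O)COc3ccc(-c4cnc(Cl)c(NS(=O)(=O)c5ccc(F)cc5)c4)cc32)cc1`: 32300 nM

All three compounds were tested in a functional assay on HeLa cells (Homo sapiens) for antiproliferative activity, read by MTT assay, with a stated time of 72 h; a higher number here means a weaker inhibitor, a lower number a stronger inhibitor. Compound 1 gives > 40000 nM, which is a limit of the assay and not a number. Of the two actual numbers, compound 3 has the higher at 32300 nM, and compound 2 lies nearest at 15600 nM.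

Compound 4 `O=C1COc2ccc(-c3cnc(Cl)c(NS(=O)(=O)c4ccc(F)cc4)c3)cc2N1c1ccccc1` has not yet been measured. Its structure differs from that of compound 3 as follows: hydrogen in place of methyl on an aromatic carbon. This is hydrogen in place of methyl on an aromatic carbon, or 4-methylphenyl to phenyl. Among the compounds with values here, two measured steps bear on it, both at the amide-type nitrogen. Hydrogen to 4-methylphenyl gave a 2.1-fold higher number from compound 2 to compound 3 (0.32 log units; beyond the scatter), while 3-methoxyphenyl to 4-methylphenyl gave an at least 1.2-fold lower number from compound 1 to compound 3 (0.09 log units; that floor lies within the scatter). Within the data shown here, no measured step removes this methyl alone, and compound 4 keeps a phenyl ring on that nitrogen, so no step beyond the scatter is expected in this assay. The expected change is a 1.1-fold lower number from compound 3 to compound 4 (0.03 log units; within the scatter). For compound 4 the estimate is 30000 nM, with an expected range of 16000 nM to 55000 nM.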

Compound 4, half-maximal inhibitory concentration: 10300 nM
Estimate against measurement, compound 4: 2.9-fold (0.46 log units) above; the whole stated range lies above it.
By their numbers in this assay, from the lowest: compounds 4 and 2 (each within the scatter of the next); then compound 3. At a limit, above all of these: compound 1.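

In this assay, within the data shown here, hydrogen in place of methyl on the aromatic carbon para to a large group gives a 3.1-fold lower number from compound 3 to compound 4 (0.50 log units; beyond the scatter), the first step in which this methyl alone changes and the change lies beyond the scatter. With phenyl on the amide-type nitrogen, the step from hydrogen stays within the scatter, at a 1.5-fold lower number from compound 2 to compound 4 (0.18 log units; within the scatter), so among these compounds the higher number of compound 3 goes with the methyl and not with the ring on that nitrogen. Hydrogen in place of methoxy gives an at least 3.8-fold lower number from compound 1 to compound 4 (0.58 log units; beyond the scatter), though the starting value of that step is a limit of the assay and not a number: the limit of > 40000 nM in this assay, at which 1 of the 4 values shown sits.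

The compounds shown leave open whether a chlorine, a hydroxyl or an ethyl group at this place would track methyl or hydrogen. They also give no cause for the step.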